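This account rests on a few compounds, and the source may have more. Where it says the series, first, only, none or still open, it means among the compounds named here.

Compound 1 `Cn1cc(C2=C(c3nn(CCCN4CCCCC4)c4ncccc34)C(=O)N(c3ccccn3)C2=O)c2ccccc21`: > 100000 nM (a limit)
Compound 2 `Cn1cc(C2=C(c3nn(CCCN4CCCCC4)c4ncccc34)C(=O)NC2=O)c2ccccc21`: 7670 nM

Among the measured compounds shown here, in a functional assay on SMMC-7721 cells (Homo sapiens) for antiproliferative activity, read by MTT assay, with a stated time of 48 h (a higher number here means a weaker inhibitor, a lower number a stronger inhibitor), compound 2 gives 7670 nM, the only true number so far. Compound 1 reaches only a limit of the assay, > 100000 nM.

Compound 3 `COc1ccc(N2C(=O)C(c3cn(C)c4ccccc34)=C(c3nn(CCCN4CCCCC4)c4ncccc34)C2=O)cc1` keeps the core of compound 2 but has 4-methoxyphenyl in place of hydrogen on an amide-type nitrogen in a ring.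

For the measured compounds named here, one measured step bears on this place: an at least 13-fold lower number from compound 1 to compound 2 (1.11 log units; beyond the scatter). That step removes pyridin-2-yl and leaves hydrogen, so compound 3 goes the opposite way, putting a group back on that nitrogen. A large move towards a higher number, meaning a weaker inhibitor, is therefore expected, though this rests on a single step with a different group. The expected change is a 4.6-fold higher number from compound 2 to compound 3 (0.66 log units; beyond the scatter). Compound 3 is estimated at 35000 nM, with an expected range of 9000 nM to 100000 nM.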

Compound 3, half-maximal inhibitory concentration: 1740 nM
Compound 3: the middle estimate sits 20-fold (1.30 log units) above what was measured; the whole stated range lies above it.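

In this assay a group on the amide-type nitrogen in a ring need not weaken the compound: 4-methoxyphenyl gives a 4.4-fold lower number from compound 2 to compound 3 (0.64 log units; beyond the scatter) and so moves towards a stronger inhibitor. Compound 1 goes against any rule that a group here always helps, so the identity of the group matters, not just its presence, and the swap of pyridin-2-yl for 4-methoxyphenyl gives an at least 57-fold lower number from compound 1 to compound 3 (1.75 log units; beyond the scatter) in the same assay. As far as these compounds go, the true size of that swap stays unknown, since the value of compound 1 is only a limit: the limit of > 100000 nM in this assay, at which 1 of the 3 values shown sits.

From the compounds shown here alone, it remains open whether a small methyl or a chain ending in an amine on this nitrogen would behave the same way. Nor do these compounds tell whether plain phenyl would do as well as 4-methoxyphenyl.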